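The compounds below may be only part of what the source reports. "The series", "measured", "known", "first", "only" and "open" are said of these compounds alone.

Series notes. In a physicochemical assay for solubility, using the shake flask method, measured as kinetic solubility, at pH 7.4 (a higher number here means a more soluble compound, a lower number a less soluble compound), compound 1 `O=C(O)c1ccc(-c2csc(-c3ccccc3F)n2)cc1` gives 38400 nM, compound 2 `O=C(O)c1cccc(-c2csc(Nc3ccccc3F)n2)c1` gives 80900 nM, and compound 3 `OCc1cccc(-c2csc(Nc3ccccc3F)n2)c1` gives 30900 nM. Going by the values given here, the only single-point step measured so far runs a 2.6-fold lower number from compound 2 to compound 3 (0.42 log units; beyond the scatter). Compound 3 thus holds the lowest of the three numbers, though its gap to compound 1 lies within the scatter and only its gap to compound 2 lies beyond it. Compound 4 `Fc1cccc(-c2csc(Nc3ccccc3F)n2)c1` differs from compound 3 by fluoro in place of hydroxymethyl on an aromatic carbon. Among the compounds with values here, no measured step removes a hydroxymethyl; the nearest comparison is the modest drop seen from compound 2 to compound 3, and on that thin basis a further small fall in this assay is expected rather than none. The expected step is a 2.1-fold lower number from compound 3 to compound 4 (0.31 log units; beyond the scatter). For compound 4 the estimate is 15000 nM, with a range from 5000 nM to 40000 nM.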

Compound 4, solubility: < 1000 nM
Compound 4: only a limit was reported; the forecaster's own chance of this, stated with the estimate: 5%; middle value at least 15-fold (1.17 log units) away from the limit.
By their numbers in this assay, from the lowest: compounds 3 and 1 (each within the scatter of the next); then compound 2. At a limit, below all of these: compound 4.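

Fluoro in place of hydroxymethyl, on an aromatic carbon meta to a large group, gives an at least 30-fold lower number from compound 3 to compound 4 (1.48 log units; beyond the scatter) in this assay, and fluoro in place of carboxy at the same carbon gives an at least 80-fold lower number from compound 2 to compound 4 (1.90 log units; beyond the scatter). Exchanging carboxy for hydroxymethyl there moved the number far less, with a 2.6-fold lower number from compound 2 to compound 3 (0.42 log units; beyond the scatter). The reading for compound 4 is a limit and not a number: the limit of < 1000 nM in this assay, at which 1 of the 4 values shown sits.

From the compounds shown here alone, how far compound 4 lies under that limit stays open. Also open, going by these compounds, is whether an amine or a longer chain ending in hydroxyl at this carbon would keep the number near that of compound 3.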